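A few compounds are considered here, and "the series" means these few. Any claim that something is new, unique, unknown or untested is made for them only; others in the source may bear on it.

Three compounds share one core and were tested in a functional assay on HeLa cells (Homo sapiens) for cytotoxicity, with a stated time of 72 h; on this read-out higher numbers stand for weaker inhibition and lower numbers for stronger inhibition. Compound 1, `Cc1ccc(-c2cn3nc(Cc4ccc(Cl)cc4)sc3n2)cc1`, gives > 250000 nM, which is a limit of the assay rather than a number. Compound 3, `Clc1ccc(Cc2nn3cc(-c4ccccc4)nc3s2)cc1`, likewise gives > 250000 nM, again a limit. Among the compounds with values here, compound 2, `Clc1ccc(Cc2nn3cc(-c4ccc(Cl)cc4Cl)nc3s2)cc1`, gives 109000 nM, the only plain number among the three, and so stands alone as the one compound with a readable value. The measured steps run an at least 2.2-fold lower number from compound 1 to compound 2 (0.36 log units; beyond the scatter), an at least 2.2-fold higher number from compound 2 to compound 3 (0.36 log units; beyond the scatter), and a step that the two limits leave unreadable from compound 1 to compound 3; all three concern the aryl group carried by the core, and two of them rest on (the limit of > 250000 nM in this assay, at which 2 of the 3 values shown sit).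

Compound 4, `Clc1ccc(Cc2nn3c(Br)c(-c4ccc(Cl)cc4Cl)nc3s2)cc1`, differs from compound 2 in a different place: bromo in place of hydrogen on an aromatic carbon. Within the data shown here, no measured step touches this position, so the change is untested here, and the expectation for compound 4 is a step of about a 1.2-fold lower number from compound 2 to compound 4 (0.08 log units; within the scatter), within the scatter. Compound 4 is therefore estimated at 90000 nM, between 30000 nM and 250000 nM.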

Compound 4, half-maximal inhibitory concentration: 118000 nM
For compound 4 the middle estimate is 1.3-fold (0.12 log units) below the measured one; the range from low to high includes it.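

In this assay, within the data shown here, this position on the five-membered aromatic ring with 2 nitrogen is read for the first time, and bromo in place of hydrogen gives a 1.1-fold higher number from compound 2 to compound 4 (0.03 log units; within the scatter). Both ends of this step are plain numbers, so its size can be read directly, and it shows that a single bromine atom at this place leaves the read-out unmoved beyond the usual scatter, at least with the 2,4-dichlorophenyl group on the core. The other two compounds give only a limit: the limit of > 250000 nM in this assay, at which 2 of the 4 values shown sit.

On these data alone, whether an amine, a carboxylic acid or a longer chain at this same carbon would also leave the read-out unmoved remains open. So does whether bromo would behave in the same way alongside a phenyl or 4-methylphenyl group.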